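The source may report more compounds than this note shows. Statements on the series, on what has been measured and on what is new or still open speak of the compounds shown alone.

Compound 3 `CC(O)(C(=O)Nc1ccc(C(=O)c2ccccc2)cc1O)C(F)(F)F` gives 15000 nM in a functional assay (Cavia porcellus) with sulfonylurea receptors; K-ATP channels (Homo sapiens) as the target (a higher number here means a weaker inhibitor, a lower number a stronger inhibitor), the highest of the three numbers measured. Compound 1 `CC(O)(C(=O)Nc1ccc(S(=O)(=O)c2ccccc2)c(C#N)c1)C(F)(F)F` gives 3800 nM in this assay, and compound 2 `CC(O)(C(=O)Nc1ccc(S(=O)(=O)c2ccccc2)c(O)c1)C(F)(F)F` gives 430 nM. Among the measured compounds shown here, the one measured step, an 8.8-fold lower number from compound 1 to compound 2 (0.95 log units; beyond the scatter), comes from a hydroxy replacing a cyano on the aromatic ring. Compound 4 `CC(O)(C(=O)Nc1ccc(C(=O)c2ccccc2)cc1Br)C(F)(F)F` is compound 3 with bromo in place of hydroxy on an aromatic carbon. For the measured compounds named here, no measured pair exchanges a hydroxy for a bromo, so that step speaks only loosely here: it shows that a hydroxy on this ring can matter, but not what a bromo does. The expected step is therefore small, a 1.5-fold lower number from compound 3 to compound 4 (0.18 log units; within the scatter), with wide uncertainty. Compound 4 is estimated at 10000 nM, within 3000 nM to 40000 nM.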

Compound 4, half-maximal inhibitory concentration: > 30000 nM
Compound 4 ended at the assay's limit (the forecaster's own chance of this, stated with the estimate: 10%); at least 3.0-fold (0.47 log units) between middle value and limit.
By their numbers in this assay, from the lowest: compound 2; then compound 1; then compound 3. At a limit, above all of these: compound 4.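

In this assay, compound 4 gives > 30000 nM, which is a limit of the assay and not a number. The exchange of hydroxy for bromo on this carbon, ortho to a large group, gives an at least 2.0-fold higher number from compound 3 to compound 4 (0.30 log units; that floor lies within the scatter). Among the compounds shown here, this is the only measured change at this position, and it gives no sign that bromo strengthens inhibition, though its true size stays unknown.

As far as these compounds go, whether an amine or a methoxy group on this carbon would do better remains open. So does whether bromo would act the same way on the core of compound 2.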